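The source may report more compounds than this note shows. Statements on the series, on what has been measured and on what is new or still open speak of the compounds shown alone.

Series notes, an assay on LtK cells with ATP-sensitive inward rectifier potassium channel 11 (Homo sapiens) as the target; a higher number here means that more compound is needed for the effect, a lower number that less compound is needed:

- compound 1 `CCC(C)C(=O)Nc1c(C(O)(C(F)(F)F)C(F)(F)F)ccc2ccccc12`: 177000 nM
- compound 2 `O=C(Nc1c(C(O)(C(F)(F)F)C(F)(F)F)ccc2ccccc12)C1CCC1`: 45 nM
- compound 3 `O=C(Nc1c(C(O)(C(F)(F)F)C(F)(F)F)ccc2ccccc12)c1ccccc1Cl`: 2040 nM

Compound 2 gives the lowest number of the three in this assay; the nearest is compound 3, a 45-fold higher number from compound 2 to compound 3 (1.66 log units; beyond the scatter), and the furthest is compound 1, a 3900-fold lower number from compound 1 to compound 2 (3.59 log units; beyond the scatter).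

Compound 4 `O=C(Nc1c(C(O)(C(F)(F)F)C(F)(F)F)ccc2ccccc12)c1ccc(F)cc1` differs from compound 2 in one place: 4-fluorophenyl in place of cyclobutyl on a carbonyl carbon.

The step that bears on this change is a 45-fold higher number from compound 2 to compound 3 (1.66 log units; beyond the scatter), which also exchanged cyclobutyl for an aromatic six-membered ring at the same carbonyl carbon. Among the compounds with values here, the step of an 87-fold lower number from compound 1 to compound 3 (1.94 log units; beyond the scatter) shows only that such an aryl group beats sec-butyl there. Compound 4 is therefore expected to show a clearly higher number than compound 2 in this assay, on the order of an 18-fold higher number from compound 2 to compound 4 (1.25 log units; beyond the scatter). The estimate for compound 4 is 800 nM, with a range from 120 nM to 5000 nM.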

Compound 4, half-maximal effective concentration: 70 nM
Compound 4: middle estimate off by 11-fold (1.06 log units), on the high side; measured number below the stated range.
By their numbers in this assay, from the lowest: compounds 2 and 4 (each within the scatter of the next); then compound 3; then compound 1.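

In this assay, 4-fluorophenyl on the carbonyl carbon matches cyclobutyl within the scatter (a 1.6-fold higher number from compound 2 to compound 4 (0.19 log units; within the scatter)), so an aromatic ring at this position is not in itself penalised, and the penalty seen with compound 3 is specific to 2-chlorophenyl (a 29-fold lower number from compound 3 to compound 4 (1.46 log units; beyond the scatter)). Sec-butyl stands apart from this aryl group as well (a 2500-fold lower number from compound 1 to compound 4 (3.40 log units; beyond the scatter)). No measurement here explains these differences.

Halogen identity and ring placement change together between compound 3 and compound 4, so 2-fluorophenyl and 4-chlorophenyl would be needed to separate them. From the compounds shown here alone, the response to unsubstituted phenyl or to an amine on the ring remains open.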